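Side-chain length and tolerated concentration in the series

The compounds below may be only part of what the source reports. "The series", "measured", "known", "first", "only" and "open" are said of these compounds alone.

Measured compounds:
compound 1 `CCCCCCCCc1cc2cn([C@H]3C[C@H](O)[C@@H](CO)O3)c(=O)nc2o1`: > 50000 nM
compound 2 `C=CCCCc1cc2cn([C@H]3C[C@H](O)[C@@H](CO)O3)c(=O)nc2o1`: > 200000 nM

In a functional assay on HEL cells (Homo sapiens) for cytotoxicity, read by microscopy (a higher number here means that more compound is tolerated, a lower number that less compound is tolerated), compound 1 gives > 50000 nM, which is a limit of the assay and not a number. In this assay compound 2 gives > 200000 nM, again a limit and not a number. Within the data shown here, compound 2 therefore stands only at a limit, and the one further value shown is also a limit: the limit of > 200000 nM in this assay, at which 1 of the 2 values shown sits. The other limit reads (the limit of > 50000 nM in this assay, at which 1 of the 2 values shown sits). The step that the two limits leave unreadable from compound 1 to compound 2 is thus not readable in size or direction.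

Compound 3 `C=CCCCCc1cc2cn([C@H]3C[C@H](O)[C@@H](CO)O3)c(=O)nc2o1` has not yet been measured in this assay. It differs from compound 2 as follows: allyl in place of vinyl on a saturated chain carbon, three bonds along the chain from an aromatic carbon. Among the measured compounds shown here, the only measured step that bears on this change is the one from compound 1 to compound 2, and its size is unreadable, so no step beyond the usual scatter is expected in this assay. Compound 3 is expected to give 100000 nM, with a range from 50000 nM to 400000 nM. The expected step is an at least 2.0-fold lower number from compound 2 to compound 3 (0.30 log units; that floor lies within the scatter), and most likely only a limit will be reported for compound 3.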

Compound 3, minimum cytotoxic concentration: > 200000 nM
Compound 3 gave a limit, no number (the forecaster's own chance of this, stated with the estimate: 85%); middle value at least 2.0-fold (0.30 log units) from the limit.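

In this assay compound 3 gives > 200000 nM, a limit and not a number. Among these compounds, no step among compound 1, compound 2 and compound 3 can be read from these limits. The compounds shown leave open whether side-chain length shifts the tolerated concentration at all.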